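The compounds below may be only part of what the source reports. "The series", "measured", "known", "first", "only" and "open" are said of these compounds alone.

Three compounds share one core and differ only in the chain attached to an oxygen on the aromatic ring. Compound 1 `C=CCc1cc(C(C)=O)c(O)cc1OCCCCCCCC#N` gives 52% in an assay on isolated protein for binding affinity to leukotriene B4 receptor 1 (Homo sapiens), tested at 1 uM; a lower number here means less inhibition, a higher number more inhibition at the concentration tested (going by the name of the read-out). Compound 2 `C=CCc1cc(C(C)=O)c(O)cc1OCCCCCCCCCCC#N` gives 14%, and compound 3 `C=CCCCCOc1cc(O)c(C(C)=O)cc1CC=C` gives 27%. Compound 3 thus stands second of the three numbers, beyond the scatter from both neighbours: compound 2 lies a number 13 percentage points higher from compound 2 to compound 3 (beyond the scatter) and compound 1 lies a number 25 percentage points lower from compound 1 to compound 3 (beyond the scatter).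

Compound 4 `C=CCc1cc(C(C)=O)c(O)cc1OCCCCCC(=O)N(C)C` has not yet been measured. It differs from compound 3 in one place: (dimethylcarbamoyl)methyl in place of vinyl on a saturated chain carbon, four bonds along the chain from an oxygen on an aromatic ring. Going by the values given here, two measured steps bear on this change, since both replace a nitrile-bearing chain at the same position with vinyl. From a 3-cyanopropyl chain, the number fell by a number 25 percentage points lower from compound 1 to compound 3 (beyond the scatter); from a 6-cyanohexyl chain it rose by a number 13 percentage points higher from compound 2 to compound 3 (beyond the scatter). Among the compounds with values here, compound 4 carries a chain closer in length to the shorter one, so a rise from compound 3 of about a number 13 percentage points higher from compound 3 to compound 4 (beyond the scatter) is expected in this assay, though the amide end is new and no compound here carries it. For compound 4 the estimate is 40%, with a range from 20% to 62%.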

Compound 4, a percentage reported as inhibition, at one concentration (the size of the read-out at that concentration, not a potency): 54%
Estimate against measurement, compound 4: 14 percentage points below; measured number inside the range.
By their numbers in this assay, from the lowest: compound 2; then compound 3; then compounds 1 and 4 (each within the scatter of the next).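

In this assay, replacing vinyl with (dimethylcarbamoyl)methyl at this chain carbon, four bonds along the chain from the oxygen on the aromatic ring, gives a number 27 percentage points higher from compound 3 to compound 4 (beyond the scatter), so a nitrile at the chain end is not required for a number well above that of compound 3. The amide end in fact matches a nitrile end of the shorter kind: dimethylcarbamoyl in place of 2-cyanoethyl gives a number 2 percentage points higher from compound 1 to compound 4 (within the scatter), which leaves the two compounds indistinguishable in this test. Against the longest chain, dimethylcarbamoyl in place of 5-cyanopentyl gives a number 40 percentage points higher from compound 2 to compound 4 (beyond the scatter), which shows that two quite different chain ends can reach a similar number, while a nitrile end alone does not secure it, as compound 2 goes against any such rule.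

Still open, on these data alone, is whether a carboxylic acid or an amine at the chain end would hold the number, and whether the same dimethylcarbamoyl group would keep it on a longer chain. Nothing measured here explains why the amide end performs as it does.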